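The source may report more compounds than this note shows. Statements on the series, on what has been measured and on what is new or still open speak of the compounds shown alone.

Measured so far in an ADME assay on the whole organism (blood, Rattus norvegicus, strain Sprague-Dawley) for metabolic stability, read by LC-MS (on this read-out lower numbers stand for a shorter-lived compound and higher numbers for a longer-lived compound), two compounds:
- compound 1 `COc1cc(C=O)c(OCc2cccnc2-c2ccnn2C(C)C)cn1` gives 2.7 h
- compound 2 `CC(C)n1nccc1-c1ncccc1COc1cncc(O)c1C=O` gives 8.1 h

Of the two, compound 2 has the higher number (8.1 h), and its gap to compound 1 (2.7 h) lies beyond the scatter. Compound 3 (`COc1cncc(OCc2cccnc2-c2ccnn2C(C)C)c1C=O`) has not yet been measured. It differs from compound 2 by a single change (methyl in place of hydrogen on an oxygen on an aromatic ring): methyl in place of hydrogen on an oxygen on an aromatic ring, hydroxy to methoxy. For the measured compounds named here, no measured pair shows this change on its own, so the expectation is tentative. It rests on compound 1, which also carries a methoxy group and reads (2.7 h). A modest step down is expected (a 2.3-fold lower number from compound 2 to compound 3 (0.36 log units; beyond the scatter)), estimated to lie just beyond the scatter. In this assay the expected value for compound 3 is 3.5 h, with an estimated range from 1.3 h to 9 h.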

Compound 3, half-life: 2.5 h
Compound 3: the middle estimate sits 1.4-fold (0.15 log units) above what was measured; low and high end bracket the measured number.
By their numbers in this assay, from the lowest: compounds 3 and 1 (each within the scatter of the next); then compound 2.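

For the compounds shown here, compound 3 gives the first direct reading in this assay of methyl in place of hydrogen on an oxygen on an aromatic ring, with a 3.2-fold lower number from compound 2 to compound 3 (0.51 log units; beyond the scatter) for the change from hydroxy to methoxy. At this oxygen, then, adding a single methyl is enough to move the half-life beyond the scatter, and of this pair the hydroxy compound, compound 2, is the longer-lived. Nothing available explains the step.

This is a single pair, so the compounds shown leave open whether the same change would give a similar step elsewhere on the core or on a different core. They also leave open how an ethyl group or a longer chain on this oxygen would read, or an amine in place of the hydroxy group.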